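A new substituent on the amide nitrogen of compound 3

The compounds below may be only part of what the source reports. "The series", "measured", "known", "first", "only" and "open" are said of these compounds alone.

In an ADME assay on MT4 cells (Homo sapiens) for cytotoxicity, read by MTT assay, with a stated time of 5 days (on this read-out higher numbers stand for lower toxicity in this test and lower numbers for higher toxicity in this test), compound 1 (`Cc1cc(C)cc(S(=O)(=O)c2c(C(=O)N[C@@H]3CCN(Cc4cccnc4)C3)[nH]c3ccc(Cl)cc23)c1`) gives 36500 nM while compound 2 (`Cc1cc(C)cc(S(=O)(=O)c2c(C(=O)N[C@@H]3CCN(S(C)(=O)=O)C3)[nH]c3ccc(Cl)cc23)c1`) gives 24000 nM and compound 3 (`Cc1cc(C)cc(S(=O)(=O)c2c(C(=O)N[C@H]3CCN(CC(N)=O)C3)[nH]c3ccc(Cl)cc23)c1`) gives 28100 nM on the same read-out; compound 3 thus stands within the scatter of both others. Compound 4 (`Cc1cc(C)cc(S(=O)(=O)c2c(C(=O)NC3CN(Cc4ccccc4F)C3)[nH]c3ccc(Cl)cc23)c1`) carries 1-(2-fluorobenzyl)azetidin-3-yl in place of 1-(carbamoylmethyl)pyrrolidin-3-yl on an amide-type nitrogen. The measured changes at this place are a 1.3-fold lower number from compound 1 to compound 3 (0.11 log units; within the scatter) and a 1.2-fold higher number from compound 2 to compound 3 (0.07 log units; within the scatter) and a 1.5-fold lower number from compound 1 to compound 2 (0.18 log units; within the scatter) and all stay within the scatter. Among the compounds with values here, no measured compound carries the entering group, so the expectation is loose. The expected change in this assay is a 1.3-fold lower number from compound 3 to compound 4 (0.11 log units; within the scatter) and no step beyond the scatter is expected. Compound 4 is expected at 22000 nM (estimated range 9000 nM to 50000 nM).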

Compound 4, half-maximal cytotoxic concentration: > 238000 nM
Compound 4: a limit, no number (the forecaster's own chance of this, stated with the estimate: 15%); middle value at least 10-fold (1.03 log units) away from the limit.
By their numbers in this assay, from the lowest: compounds 2, 3 and 1 (each within the scatter of the next). At a limit, above all of these: compound 4.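

In this assay compound 4 gives no number, only a limit of the assay: the limit of > 238000 nM in this assay, at which 1 of the 4 values shown sits.

The exchanges among the pyrrolidin-3-yl groups of compounds 1, 2 and 3 all stayed within the scatter, whereas this change on the amide-type nitrogen gives steps beyond it (an at least 8.4-fold higher number from compound 3 to compound 4 (0.92 log units; beyond the scatter)) and (an at least 9.9-fold higher number from compound 2 to compound 4 (0.99 log units; beyond the scatter)) and (an at least 6.5-fold higher number from compound 1 to compound 4 (0.81 log units; beyond the scatter)). This position can therefore shift the read-out towards lower toxicity in this test.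

The azetidin-3-yl ring and the 2-fluorobenzyl group enter together, and the compounds shown do not separate them. A 1-(2-fluorobenzyl)pyrrolidin-3-yl group or an unsubstituted benzyl group on the azetidine nitrogen would tell which part carries the step.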